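Urea chain in place of cyclopropyl on the shared core

The source may report more compounds than this note shows. Statements on the series, on what has been measured and on what is new or still open speak of the compounds shown alone.

Compound 1 `COc1ncc(-c2ccc3nc(NC4CC4)sc3c2)cc1NS(=O)(=O)c1ccc(F)cc1` is the reference for this step. In a functional assay on U-87MG ATCC cells for antiproliferative activity against U-87 MG (Homo sapiens), read by MTT assay, with a stated time of 72 h (a higher number here means a weaker inhibitor, a lower number a stronger inhibitor), compound 1 gives 1500 nM, the higher of the two numbers in hand. The nearest number belongs to compound 3 `CCN(CC)CCNC(=O)Nc1nc2ccc(-c3cnc(Cl)c(NS(=O)(=O)c4ccc(F)cc4)c3)cc2s1`, which in this assay gives 1390 nM; the gap between compound 1 and compound 3 falls within the scatter, so the two read as equivalent. Compound 2 `CCCNc1nc2ccc(-c3cnc(Cl)c(NS(=O)(=O)c4ccc(F)cc4)c3)cc2s1` carries the same sulfonamide arm on the chlorinated variant of the core; in this assay compound 2 gives "not determined" (no result reported), so no number is in hand for it.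

Compound 4 `COc1ncc(-c2ccc3nc(NC(=O)NCCN4CCN(C)CC4)sc3c2)cc1NS(=O)(=O)c1ccc(F)cc1` is the next entry. The change from compound 1 is (2-(4-methylpiperazin-1-yl)ethyl)carbamoyl in place of cyclopropyl on a nitrogen on an aromatic ring. For the measured compounds named here, no step between two measured compounds isolates this change. Going by the values given here, the only guide is compound 3, whose carbamoyl-linked chain on the chlorinated core gives 1390 nM, a number indistinguishable from that of compound 1. On that basis the step from compound 1 to compound 4 in this assay is expected to stay within the scatter, with at most a modest move toward a lower number; the expected step is a 1.4-fold lower number from compound 1 to compound 4 (0.13 log units; within the scatter). Compound 4 is accordingly estimated at 1100 nM in this assay, with a range from 400 nM to 3000 nM.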

Compound 4, half-maximal inhibitory concentration: 440 nM
Compound 4: middle estimate off by 2.5-fold (0.40 log units), on the high side; measured number inside the range.
By their numbers in this assay, from the lowest: compound 4; then compounds 3 and 1 (each within the scatter of the next).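

In this assay the nitrogen on an aromatic ring now has its first readable step: a 3.4-fold lower number from compound 1 to compound 4 (0.53 log units; beyond the scatter) is modest but beyond the scatter, with cyclopropyl leaving and (2-(4-methylpiperazin-1-yl)ethyl)carbamoyl entering. The earlier compounds offered no pair differing in one place, so nothing had yet been shown about this position; it now accepts a much larger group, one that brings a six-membered non-aromatic ring with hetero atoms plus hydrogen-bond donor and acceptors, and the number goes down rather than up on the core of compound 1. Nothing measured here accounts for the step.

Which part of the entering group goes with the lower number stays open, as the carbamoyl link, the ethyl chain and the 4-methylpiperazine ring arrive together, and a morpholine ring at the chain end, a simple dimethylamine or a longer chain would each pull these parts apart. Also open, going by these compounds, is whether the same exchange carries over to the chlorinated variant of the core, where compound 2 has no number to start from.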